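The compounds below may be only part of what the source reports. "The series", "measured", "known", "first", "only" and "open" are said of these compounds alone.

Compound 1 `COc1cc2c(Oc3ccc(NC(=O)N/N=C/c4ccc(F)cc4Cl)cc3F)ccnc2cc1OCCCN1CCCCC1` gives the lowest number of the three in a functional assay on MKN-45 cells (Homo sapiens) for cytotoxicity, read by MTT assay, with a stated time of 72 h (on this read-out higher numbers stand for weaker inhibition and lower numbers for stronger inhibition), at 270 nM. Compound 2 `COc1cc2c(Oc3ccc(NC(=O)N/N=C/c4ccc(N(C)C)cc4)cc3F)ccnc2cc1OCCCN1CCCCC1` gives 870 nM, and compound 3 `COc1cc2c(Oc3ccc(NC(=O)N/N=C/c4cccs4)cc3F)ccnc2cc1OCCCN1CCCCC1` gives 740 nM. The two steps away from compound 1, a 3.2-fold higher number from compound 1 to compound 2 (0.51 log units; beyond the scatter) and a 2.7-fold higher number from compound 1 to compound 3 (0.44 log units; beyond the scatter), each swap the group on a carbon with a double bond to nitrogen, and between the other two compounds a 1.2-fold lower number from compound 2 to compound 3 (0.07 log units; within the scatter). Compound 4 `COc1cc2c(Oc3ccc(NC(=O)N/N=C/c4ccc(F)cc4Cl)cc3F)ccnc2cc1OCCCN1CCC(C)CC1` differs from compound 1 elsewhere, by methyl in place of hydrogen on a saturated ring carbon. Going by the values given here, no measured step touches that part of the shared core, so the data point in no direction for compound 4 in this assay, and the expected step is a 1.0-fold higher number from compound 1 to compound 4 (0.02 log units; within the scatter). Compound 4 is therefore estimated at 280 nM, within a range from 120 nM to 650 nM.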

Compound 4, half-maximal inhibitory concentration: 530 nM
Compound 4: the middle estimate sits 1.9-fold (0.28 log units) below what was measured; the measured number falls inside the stated range.
By their numbers in this assay, from the lowest: compounds 1, 4, 3 and 2 (each within the scatter of the next, the first and the last beyond it).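

In this assay, the methyl on a saturated ring carbon, three ring bonds from the ring nitrogen, gives a 2.0-fold higher number from compound 1 to compound 4 (0.29 log units; within the scatter). This is the only step shown at the piperidin-1-yl end of compound 1, and unlike the two swaps of the group on the carbon with a double bond to nitrogen, it stays within the scatter. No evidence here speaks to a cause for this step. Still open, from the compounds shown here alone, is how a hydroxyl, an ethyl, or a morpholin-4-yl or 4-methylpiperazin-1-yl group in place of piperidin-1-yl would read. Also open, going by these compounds, is whether the methyl gives a similar step on compound 2 and compound 3.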